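The compounds below may be only part of what the source reports. "The series", "measured", "known", "first", "only" and "open" are said of these compounds alone.

In a functional assay on HCT-116 cells (Homo sapiens) for antiproliferative activity, read by sulforhodamine B assay, with a stated time of 3 days, tested at 25 uM (on this read-out higher numbers stand for a stronger effect at the one concentration tested and lower numbers for a weaker effect), compound 2 `O=C(/C=C/c1ccccc1)c1ccc(OCc2ccccc2)cc1` gives 24.3%. Going by the values given here, of the two compounds measured so far it has the higher number: the other, compound 1 `Cc1ccc(COc2ccc(C(=O)/C=C/c3ccccc3)cc2)cc1`, gives 4% in this assay. Among the compounds with values here, the single measured step, a number 20.3 percentage points higher from compound 1 to compound 2 (beyond the scatter), removes a methyl from an aromatic carbon of the benzyl ring and raises the read-out by a modest amount that lies beyond the scatter.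

Compound 3 `COc1ccc(/C=C/C(=O)c2ccc(OCc3ccccc3)cc2)cc1` has not yet been measured. Its difference from compound 2 is methoxy in place of hydrogen on an aromatic carbon, placed on an aromatic carbon of a six-membered aromatic ring of carbon only, para to a large group; read one bond further out, phenyl becomes 4-methoxyphenyl. Within the data shown here, no measured step concerns a group entering at this ring, so the one known step gives no direct guide, and the change is expected to leave this assay within the scatter in either direction. Compound 3 is therefore estimated at 25%, with a range from 5% to 50%; the expected step is a number 0.7 percentage points higher from compound 2 to compound 3 (within the scatter).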

Compound 3, a percentage reported as inhibition, at one concentration (the size of the read-out at that concentration, not a potency): 9.5%
Compound 3: the middle estimate sits 15.5 percentage points above what was measured; measured number inside the range.
By their numbers in this assay, from the lowest: compounds 1 and 3 (each within the scatter of the next); then compound 2.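

In this assay, the change from phenyl to 4-methoxyphenyl gives a number 14.8 percentage points lower from compound 2 to compound 3 (beyond the scatter). Going by these compounds alone, this is the first measured sign that the ring on this side of the molecule responds to a new group: a methoxy on an aromatic carbon, para to a large group, does not leave the read-out where it was. The earlier step, a number 20.3 percentage points higher from compound 1 to compound 2 (beyond the scatter), concerned only the benzyl ring, so compound 2, which carries neither added group, now stands above both of its one-change relatives, although nothing available explains why the read-out falls in either case.

The compounds shown leave open whether the drop belongs to methoxy itself or would follow any group at this place, as a fluorine atom, a hydroxyl, an amine or a carboxylic acid could show. They also leave open how these differences would look as potencies, since each number here describes the effect at one concentration only.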